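A naphthyl for a fluorophenyl on an inactive core

This account rests on a few compounds, and the source may have more. Where it says the series, first, only, none or still open, it means among the compounds named here.

In a functional assay on HL-60 cells (Homo sapiens), read by calcium flux (on this read-out lower numbers stand for an effect already at smaller amounts and higher numbers for an effect only at larger amounts of compound), compound 1 `COc1cccc(Cc2cc(-c3cccs3)nn(CC(=O)Nc3ccc(F)cc3)c2=O)c1` gives only a limit of > 50000 nM, not a measured number. Compound 2 `COc1cccc(Cc2cc(-c3ccc(Cl)cc3)nn(CC(=O)Nc3ccc(F)cc3)c2=O)c1` likewise reaches only a limit of > 50000 nM in this assay. Putting 4-chlorophenyl in place of thiophen-2-yl gives a step that the two limits leave unreadable from compound 1 to compound 2, a step that cannot be sized, as the limit of > 50000 nM in this assay, at which 3 of the 3 values shown sit, shows. Going by these compounds, compound 3 `Cc1cc(Cc2cccc(F)c2)c(=O)n(CC(=O)Nc2ccc(Br)cc2)n1` also sits at a limit in this assay, > 50000 nM, so where it truly stands is unknown. Compound 4 `Cc1cc(Cc2cccc3ccccc23)c(=O)n(CC(=O)Nc2ccc(Br)cc2)n1` differs from compound 3 by naphthalen-1-yl in place of 3-fluorophenyl on a saturated chain carbon bound to an aromatic carbon. Among the measured compounds shown here, no measured step involves this change, and the one measured step could not be read, so no direction can be drawn from it. The expected step in this assay is a step that the limit leaves unreadable from compound 3 to compound 4, effectively none. Compound 4 is therefore estimated at 80000 nM in this assay, within a range of 20000 nM to 300000 nM, most likely again reported only as a limit.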

Compound 4, half-maximal effective concentration: > 50000 nM
Compound 4: no number, only a limit; the forecaster's own chance of this, stated with the estimate: 85%; the middle value lies beyond the limit too.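

Among the compounds shown here, compound 3 and compound 4 both give only a limit, so no step between them can be read: the limit of > 50000 nM in this assay, at which 4 of the 4 values shown sit. The compounds shown leave open whether naphthalen-1-yl or 3-fluorophenyl makes any difference in this assay.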